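Methyl versus isopropyl on the ring amide nitrogen

A few compounds are considered here, and "the series" means these few. Any claim that something is new, unique, unknown or untested is made for them only; others in the source may bear on it.

Measured so far:
- compound 1, `COC(=O)C1=CN(C)C(=O)[C@@H]2C(CN3CCN(Cc4ccc(C(F)(F)F)cc4)CC3)=CC[C@H]12`, in a functional assay on Cortical neurone cells (Rattus norvegicus, strain Sprague-Dawley), read by MTT assay, with stated times of 24 h and 2 h, tested at 10 uM (a lower number here means a weaker effect, a higher number a stronger effect of the compound at the concentration tested), compound 1 gives 80.9%
- compound 2, `COC(=O)C1=CN(C(C)C)C(=O)[C@@H]2C(CN3CCN(Cc4cccc(C(F)(F)F)c4)CC3)=CC[C@H]12`, in this assay compound 2 gives 85.5%

Compound 2 holds the larger of the two figures, but its value and that of compound 1 lie within the usual scatter of each other, so no ordering between them is supported. Going by the values given here, no single-change step between measured compounds is available; the two values merely show that both compounds act to a similar degree at the tested concentration.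

The next compound, compound 3 `COC(=O)C1=CN(C)C(=O)[C@@H]2C(CN3CCN(Cc4cccc(C(F)(F)F)c4)CC3)=CC[C@H]12`, differs from compound 2 by methyl in place of isopropyl on an amide-type nitrogen in a ring. Nothing measured tells how this change acts. The step of a number 3.5 percentage points lower from compound 2 to compound 3 (within the scatter) is expected to be small, in either direction, and not beyond the scatter. For compound 3 in this assay the estimated value is 82%, with a range from 70% to 92%.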

Compound 3, a percentage reported as activity, at one concentration (the size of the read-out at that concentration, not a potency): 80.3%
Compound 3: middle estimate off by 1.7 percentage points, on the high side; low and high end bracket the measured number.
By their numbers in this assay, from the lowest: compounds 3, 1 and 2 (each within the scatter of the next).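

Methyl in place of isopropyl on the amide-type nitrogen in a ring gives, in this assay, a number 5.2 percentage points lower from compound 2 to compound 3 (within the scatter), so this first single-change reading at that nitrogen does not separate the two groups. 3-(Trifluoromethyl)phenyl in place of 4-(trifluoromethyl)phenyl on a saturated chain carbon bound to an amine nitrogen in a ring gives a number 0.6 percentage points lower from compound 1 to compound 3 (within the scatter), so the two trifluoromethyl placements are not separated either. No measurement at hand bears on the reason for either step.

Still open, as far as these compounds go, is whether a longer chain on this nitrogen, or the amide hydrogen in place of the alkyl group, would move the number beyond the scatter. The same question stands for a nitrile in place of trifluoromethyl on the phenyl group.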